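Replacing the aryl group at the chain carbon of compound 1

The source may hold more compounds than are shown below. What is called first, only, known or untested is meant among the compounds shown, and "the series" means these compounds.

In a functional assay on U-87MG ATCC cells for inhibition, with U-87 MG (Homo sapiens) as the target, read by MTT assay, with a stated time of 72 h (a higher number here means a weaker inhibitor, a lower number a stronger inhibitor), compound 1 (`Oc1cccc(C(Nc2ccccn2)c2ccc3cccnc3c2O)c1Cl`) gives > 10000 nM as a limit and not as a number. Compound 2 (`Oc1ccc2ncccc2c1C(c1ccc(F)cc1)N1CCCCC1`) gives 10000 nM and compound 3 (`COc1cc(C(Nc2ccc(C)cn2)c2ccc3cccnc3c2O)cc(OC)c1O`) gives 7400 nM with these two values within the usual scatter of each other. Going by the values given here, no two measured compounds differ in one place, so no measured step is available to size the next change.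

Compound 4 (`CCc1ccc(C(Nc2ccccn2)c2ccc3cccnc3c2O)cc1`) carries 4-ethylphenyl in place of 2-chloro-3-hydroxyphenyl on a saturated chain carbon bound to an aromatic carbon and a nitrogen on an aromatic ring. In this assay a modest shift toward stronger inhibition is expected, not far beyond the scatter. Among the compounds with values here, that expectation rests on compound 2 at 10000 nM and compound 3 at 7400 nM as the only numbers available. The estimated step is an at least 1.6-fold lower number from compound 1 to compound 4 (0.22 log units; that floor lies within the scatter) and stays an expectation for now. In this assay the estimate for compound 4 is 6000 nM within an expected range of 2500 nM to 15000 nM for now.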

Compound 4, half-maximal inhibitory concentration: 9300 nM
For compound 4 the middle estimate is 1.6-fold (0.19 log units) below the measured one; the range from low to high includes it.
By their numbers in this assay, from the lowest: compounds 3, 4 and 2 (each within the scatter of the next).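

Going by these compounds alone, at the saturated chain carbon, 4-ethylphenyl in place of 2-chloro-3-hydroxyphenyl gives the first readable step at this position in this assay: an at least 1.0-fold lower number from compound 1 to compound 4 (0.03 log units; that floor lies within the scatter). The oxygen and chlorine of the leaving group, with its hydrogen-bond donor and acceptor, are absent from compound 4, which still gives 9300 nM, so this pair shows that neither is needed for a measurable number. The step is only a floor because compound 1 is a limit and not a number: the limit of > 10000 nM in this assay, at which 1 of the 4 values shown sits.

On these data alone, the true size of the step stays open, and this pair cannot separate the gain of the ethyl group from the loss of the chlorine and hydroxyl. A carboxylic acid or an amine on the phenyl ring at this place would test whether this position responds to anything beyond the scatter.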